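The compounds below may be only part of what the source reports. "The series", "measured", "known", "first", "only" and "open" are said of these compounds alone.

In an assay on isolated protein for antagonist activity at Bile acid receptor (Homo sapiens), read by HTRF, with a stated time of 30 min (a lower number here means a stronger inhibitor, a higher number a weaker inhibitor), compound 1 `CC(=O)c1cc(CC(C)C)c(OCCCCCC(C)(C)c2nnn[nH]2)cc1O` gives 5800 nM and compound 2 `CCCCc1cc(C(C)=O)c(O)cc1OCCCCCC(C)(C)c1nnn[nH]1` gives 1500 nM. For the measured compounds named here, the only measured step, a 3.9-fold lower number from compound 1 to compound 2 (0.59 log units; beyond the scatter), leaves compound 2 with the lower of the two numbers. Compound 3 `CCCCCCc1cc(C(C)=O)c(O)cc1OCCCCCC(C)(C)c1nnn[nH]1` differs from compound 2 by ethyl in place of hydrogen on a saturated chain carbon, four bonds along the chain from an aromatic carbon. Going by the values given here, the one step that bears on this change in this assay is a 3.9-fold lower number from compound 1 to compound 2 (0.59 log units; beyond the scatter), a modest drop for a longer, unbranched chain. A further drop of similar or smaller size is therefore expected, a 1.7-fold lower number from compound 2 to compound 3 (0.22 log units; within the scatter). Compound 3 is estimated at 900 nM, in a range from 350 nM to 3000 nM.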

Compound 3, half-maximal inhibitory concentration: 3200 nM
Estimate against measurement, compound 3: 3.6-fold (0.55 log units) below; measured number outside the range, above it.
By their numbers in this assay, from the lowest: compound 2; then compounds 3 and 1 (each within the scatter of the next).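

In this assay, ethyl in place of hydrogen at this chain carbon reverses the earlier drop (a 2.1-fold higher number from compound 2 to compound 3 (0.33 log units; beyond the scatter)). Lengthening the unbranched chain therefore does not keep lowering the number, and compound 2 remains the lowest of the three. The longer chain also gives no clear separation from the branched chain of compound 1 (a 1.8-fold lower number from compound 1 to compound 3 (0.26 log units; within the scatter)), and no measured evidence explains this turn.

From the compounds shown here alone, whether a pentyl chain or a cyclopropyl group in place of the chain would give a lower number than compound 2 remains open. So does whether an amine or a carboxylic acid on this chain would be tolerated.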